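The compounds below may be only part of what the source reports. "The series", "measured", "known", "first", "only" and "open" are said of these compounds alone.

In a functional assay on HCT-116 cells (Homo sapiens) for inhibition, read by CCK-8 assay, with a stated time of 48 h (on this read-out lower numbers stand for stronger inhibition and higher numbers for weaker inhibition), two compounds sharing the same core have been measured. Compound 1 (`COc1cc(-c2ccnc3cc(-c4ccc5cc[nH]c5c4)nn23)cc(OC)c1OC`), which carries 1H-indol-6-yl, gives 187 nM. Compound 2 (`COc1cc(-c2ccnc3cc(-c4ccc(C(F)(F)F)cc4)nn23)cc(OC)c1OC`), with 4-(trifluoromethyl)phenyl in its place, gives 1860 nM, the higher and therefore weaker of the two numbers. Among the compounds with values here, the only measured step, a 9.9-fold higher number from compound 1 to compound 2 (1.00 log units; beyond the scatter), lies beyond the scatter. Compound 3 (`COc1ccc(-c2cc3nccc(-c4cc(OC)c(OC)c(OC)c4)n3n2)cc1`) has methoxy in place of trifluoromethyl on an aromatic carbon, (methoxy in place of trifluoromethyl on an aromatic carbon). Within the data shown here, no measured step makes this exact change, so the one available step offers only a rough scale: swapping the group at this end of the molecule can matter. Among the measured compounds shown here, compound 2 holds the higher of only two numbers, so a modest move towards compound 1 is expected, a 3.1-fold lower number from compound 2 to compound 3 (0.49 log units; beyond the scatter), though this is uncertain. The value for compound 3 is estimated at 600 nM, with an expected range from 130 nM to 2500 nM.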

Compound 3, half-maximal inhibitory concentration: 404 nM
Estimate against measurement, compound 3: 1.5-fold (0.17 log units) above; the range from low to high includes it.
By their numbers in this assay, from the lowest: compound 1; then compound 3; then compound 2.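

In this assay methoxy in place of trifluoromethyl, on an aromatic carbon para to a large group, gives a 4.6-fold lower number from compound 2 to compound 3 (0.66 log units; beyond the scatter) and so shows that this end of the molecule responds to a change in one substituent, not only to exchanging the whole aromatic group. Replacing 1H-indol-6-yl with 4-methoxyphenyl gives a 2.2-fold higher number from compound 1 to compound 3 (0.33 log units; beyond the scatter) and places compound 3 closer to compound 1 than compound 2 is, although compound 1 still has the lowest number of the three. Nothing measured alongside these numbers explains the differences.

As far as these compounds go, it remains open how an amine or a carboxylic acid at this place on the ring would compare with methoxy and trifluoromethyl. From the compounds shown here alone, it is also open whether ethoxy, with its longer chain, would give a number near that of compound 3.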